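The source may report more compounds than this note shows. Statements on the series, on what has been measured and on what is new or still open speak of the compounds shown alone.

The measured compounds, with their values in a functional assay on L1210 cells (Mus musculus); on this read-out higher numbers stand for weaker inhibition and lower numbers for stronger inhibition:

Compound 1, `C#Cc1cn(C2O[C@H](CO)[C@@H](O)[C@@H]2O)c(=O)[nH]c1=O`, gives 45 ug/mL.
Compound 2, `CCC#Cc1cn([C@H]2C[C@H](O)[C@@H](CO)O2)c(=O)[nH]c1=O`, gives > 1000 ug/mL, which is a limit of the assay and not a number.
Compound 3, `CC(C)(C)C#Cc1cn(C2O[C@H](CO)[C@@H](O)[C@H]2O)c(=O)[nH]c1=O`, gives 300 ug/mL.

Compound 2 stands at the limit of > 1000 ug/mL in this assay, at which 1 of the 3 values shown sits; it is the only one of the three that reports no number, so its place against compound 1 and compound 3 can only be given as sitting at the limit. For the measured compounds named here, no step between two measured compounds that differ in one place is available here. Compound 4, `CCCCCCc1cn([C@H]2C[C@H](O)[C@@H](CO)O2)c(=O)[nH]c1=O`, differs from compound 2 by hexyl in place of but-1-yn-1-yl on an aromatic carbon. Going by the values given here, with no measured step to lean on, and with compound 2 already at the limit, the account expects the change to bring no step beyond the scatter in this assay, in either direction. Compound 4 is therefore expected to give about 1000 ug/mL, in a range from 300 ug/mL to 3000 ug/mL. The estimated step of a number no higher from compound 2 to compound 4 (the limit leaves the size open) is thus expected to be no more than the scatter.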

Compound 4, concentration for 50% inhibition: 301 ug/mL
Compound 4: middle estimate off by 3.3-fold (0.52 log units), on the high side; the range from low to high includes it.
By their numbers in this assay, from the lowest: compound 1; then compounds 3 and 4 (each within the scatter of the next). At a limit, above all of these: compound 2.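

In this assay, for the compounds shown here, hexyl in place of but-1-yn-1-yl on the aromatic carbon two atoms from the ring nitrogen brings an at least 3.3-fold lower number from compound 2 to compound 4 (0.52 log units; beyond the scatter) and gives this position its first reading, since no earlier pair differed in one place. The read-out therefore responds to the chain at this position, and a chain without a triple bond outside aromatic rings returns a number rather than a limit. Going by these compounds, the step has only a bound, so its full size stays open: the limit of > 1000 ug/mL in this assay, at which 1 of the 4 values shown sits.

The swap removes the triple bond and changes the chain length in one move, so the compounds shown leave open which of the two carries the step. Also open, on these data alone, is how a butyl group, an octyl chain or a chain ending in an amine would read on the same carbon.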